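The compounds below may be only part of what the source reports. "The series", "measured", "known", "first", "only" and "open" are said of these compounds alone.

Measured so far:
compound 1 `CN1CCC(C(=O)N2Cc3c(NC(=O)c4cc(F)cc(F)c4)n[nH]c3C2(C)C)CC1`: 130 nM
compound 2 `CC(=O)N1CCC(C(=O)N2Cc3c(NC(=O)c4ccc(F)cc4)n[nH]c3C2(C)C)CC1`: > 10000 nM

Within the data shown here, in a functional assay on A2780 cells (Homo sapiens) for antiproliferative activity, read by fluorescence, with a stated time of 72 h (a lower number here means a stronger inhibitor, a higher number a weaker inhibitor), compound 1 holds the only true number, 130 nM. For compound 2, the entry > 10000 nM is a limit of the assay and not a number.

Compound 3 `CN1CCC(C(=O)N2Cc3c(NC(=O)c4ccco4)n[nH]c3C2(C)C)CC1` has yet to be measured. It differs from compound 1 by one change: furan-2-yl in place of 3,5-difluorophenyl on a carbonyl carbon. In words, furan-2-yl stands in place of 3,5-difluorophenyl on a carbonyl carbon. Among the measured compounds shown here, no measured pair shows what this change does, so any forecast is loose. A moderate weakening in this assay is expected, just beyond the usual scatter, and the estimated step is a 3.1-fold higher number from compound 1 to compound 3 (0.49 log units; beyond the scatter). The estimate for compound 3 is 400 nM, with an expected range of 100 nM to 1800 nM.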

Compound 3, half-maximal inhibitory concentration: > 5000 nM
Compound 3: a limit, no number (the forecaster's own chance of this, stated with the estimate: 8%); at least 12-fold (1.09 log units) between middle value and limit.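

In this assay compound 3 gives > 5000 nM, a limit of the assay and not a number. Furan-2-yl in place of 3,5-difluorophenyl on a carbonyl carbon gives an at least 38-fold higher number from compound 1 to compound 3 (1.58 log units; beyond the scatter), so the group at this place strongly affects the activity of compound 1. Among these compounds, this is the first single-change comparison here, and it shows that the shared core and the rest of compound 1 do not keep that activity without the 3,5-difluorophenyl.

From the compounds shown here alone, the full size of the loss stays unknown. One pair also cannot separate the fluorines, the ring size and the ring oxygen; an unsubstituted phenyl or a thiophen-2-yl at this place would help to pull these apart.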